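Series notes: inverting the stereocentre from compound 2 to compound 4

The compounds below may be only part of what the source reports. "The series", "measured", "known", "first", "only" and "open" are said of these compounds alone.

Of the compounds shown here, three have been measured in a functional assay on DU-145 cells (Homo sapiens) for cytotoxicity, read by MTT assay; on this read-out higher numbers stand for weaker inhibition and lower numbers for stronger inhibition. Compound 2 `CC(C)C[C@H](NC(=S)NCc1ccccc1)c1nc2ccccc2[nH]1` gives 21100 nM, the lowest number of the three. Among the compounds with values here, compound 1 `CC(C)C[C@H](NC(=S)Nc1ccccc1)c1nc2ccccc2[nH]1` gives 28900 nM; the one recorded step, a 1.4-fold lower number from compound 1 to compound 2 (0.14 log units; within the scatter), is within the scatter, so compounds 1 and 2 are not separated on this read-out. Within the data shown here, compound 3 `C[C@H](NC(=S)Nc1cc(C(F)(F)F)cc(C(F)(F)F)c1)c1nc2ccccc2[nH]1` gives 154000 nM, a number beyond the scatter from compound 2, but compound 3 differs from compound 2 in more than one place and no single step connects them.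

Compound 4 `CC(C)C[C@@H](NC(=S)NCc1ccccc1)c1nc2ccccc2[nH]1` is the next candidate. Relative to compound 2: the two compounds have the same atoms and bonds and differ only in configuration as drawn: 1 of 1 stereo elements differ; a stereocentre at a saturated chain carbon is drawn S in compound 2 and R in compound 4. Among the measured compounds shown here, no measured step concerns a change of configuration; the only recorded step, benzyl in place of phenyl on an amide-type nitrogen, is within the scatter and does not bear on compound 4. With nothing to anchor a direction in this assay, the expectation is a step of no set direction, plausibly within the scatter, but with wider uncertainty than a repeat measurement would carry. Compound 4 is therefore estimated at 30000 nM, with a range of 10000 nM to 90000 nM. The expected step is a 1.4-fold higher number from compound 2 to compound 4 (0.15 log units; within the scatter).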

Compound 4, half-maximal inhibitory concentration: 21200 nM
The estimate for compound 4 lay 1.4-fold (0.15 log units) above the measured number; measured number inside the range.
By their numbers in this assay, from the lowest: compounds 2, 4 and 1 (each within the scatter of the next); then compound 3.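

The step in this assay is a 1.0-fold higher number from compound 2 to compound 4 (0.00 log units; within the scatter), so the two configurations at this saturated chain carbon are not separated on this read-out. Within the data shown here, the earlier compounds offered no pair at this position in which configuration was the only change, and this pair isolates that change: the fact that compounds 2 and 4 differ only in the configuration as drawn. Among these compounds, with the benzyl group on the amide-type nitrogen, the drawn configuration at this carbon therefore leaves no readable mark on the number, and the stereocentre gives no handle for separating compounds in this part of the series.

This reading rests on a single pair carrying the benzyl group, and it leaves open whether configuration stays equally silent with the phenyl group of compound 1 or with the two trifluoromethyl groups of compound 3. Also open, on these data alone, is what a longer chain at the stereocentre, or an amine or a carboxylic acid on the benzyl group, would do to the number in this assay.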